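Nitrothiophene amines: a carbamoyl for a benzyl

The compounds below may be only part of what the source reports. "The series", "measured", "known", "first", "only" and "open" are said of these compounds alone.

Compound 1 `CC(C)(C)OC(=O)CN(Cc1ccc2ccccc2c1)Cc1ccc([N+](=O)[O-])s1` — a functional assay on HEK293 cells for agonist activity at nuclear receptor subfamily 1 group D member 1 (Homo sapiens), read by a luciferase reporter, with a stated time of 24 h; on this read-out lower numbers stand for an effect already at smaller amounts and higher numbers for an effect only at larger amounts of compound: "not determined" (no result reported)
Compound 2 `O=[N+]([O-])c1ccc(CN(Cc2ccc(Cl)cc2)Cc2nc3ccccc3s2)s1` — this assay: 4000 nM
Compound 3 `O=[N+]([O-])c1ccc(CN(Cc2ccc(Cl)cc2)CC2CCN(Cc3ccccc3)C2)s1` — this assay: "not determined" (no result reported)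

Three compounds of this series have been examined, all sharing the nitrothiophene-bearing tertiary amine. In this assay compound 2 gives 4000 nM. For compound 1 the record reads "not determined" (no result reported). Going by the values given here, compound 3 likewise has no single number in this assay, so it cannot be placed against compound 2 on the scale, and no step between measured compounds can be stated.

Compound 4 `CCCCNC(=O)N1CCC(CN(Cc2ccc(Cl)cc2)Cc2ccc([N+](=O)[O-])s2)C1` differs from compound 3 in one place: butylcarbamoyl in place of benzyl on an amine nitrogen in a ring. Among the compounds with values here, with no number for compound 3 and no comparable step among the measured compounds, the size and direction of this change in this assay cannot be read from the data; the only measured anchor is compound 2.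

Within the data shown here, compound 4 is therefore expected to land near the one number the series shows, at an estimated 4000 nM, within a range of 800 nM to 20000 nM.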

Compound 4, half-maximal effective concentration: 670 nM
Compound 4: middle estimate off by 6.0-fold (0.78 log units), on the high side; measured number outside the range, below it.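

Going by these compounds alone, no step from compound 3 to compound 4 can be read in this assay, where compound 3 has no single number. The compounds shown leave open what butylcarbamoyl in place of benzyl does to the read-out, and no evidence bearing on a cause is available.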